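The compounds below may be only part of what the source reports. "The series", "measured", "known", "first", "only" and "open" are said of these compounds alone.

In a functional assay on MCF7 cells (Homo sapiens) for cytotoxicity, read by MTT assay, with a stated time of 96 h (a higher number here means a weaker inhibitor, a lower number a stronger inhibitor), three compounds have been measured: compound 1 `COc1cc(C(=O)c2cn(-c3cccc(F)c3)cc2-c2ccccc2[N+](=O)[O-])cc(OC)c1OC` gives 190 nM; compound 2 `COc1cc(C(=O)c2cn(-c3cccc(N)c3)cc2-c2ccccc2[N+](=O)[O-])cc(OC)c1OC` gives 14 nM; compound 3 `COc1cc(C(=O)c2cn(-c3ccc(F)cc3)cc2-c2ccccc2F)cc(OC)c1OC` gives 39 nM.

Compound 2 differs from compound 1 by one change, (amino in place of fluoro on an aromatic carbon), and that change brought a 14-fold lower number from compound 1 to compound 2 (1.13 log units; beyond the scatter). Compound 4 `COc1cc(C(=O)c2cn(-c3ccc(N)cc3)cc2-c2ccccc2F)cc(OC)c1OC` carries the same kind of change on the core of compound 3: amino in place of fluoro on an aromatic carbon. The place is not identical, though: in compound 2 the amino sits meta to a large group, in compound 4 para to a large group. The difference between the two cores is not broken down here. Compound 4 is therefore expected to give a step of a 3.9-fold lower number from compound 3 to compound 4 (0.59 log units; beyond the scatter), somewhat smaller than the earlier one because a 14-fold lower number from compound 1 to compound 2 (1.13 log units; beyond the scatter) came from a different core and a different place. The expected value for compound 4 is 10 nM, with a likely range from 3 nM to 30 nM.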

Compound 4, half-maximal inhibitory concentration: 28 nM
The estimate for compound 4 lay 2.8-fold (0.45 log units) below the measured number, within the range that was stated.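

In this assay, amino in place of fluoro gave a 1.4-fold lower number from compound 3 to compound 4 (0.14 log units; within the scatter), so on this core the swap makes no clear difference. The same swap therefore does not carry over at the same size from one core to the other: the same change on two cores in this assay, a 14-fold lower number (1.13 log units; beyond the scatter) from compound 1 to compound 2 and a 1.4-fold lower number (0.14 log units; within the scatter) from compound 3 to compound 4, 9.7-fold (0.99 log units) apart, beyond the scatter of two such steps

For the compounds shown here, with only two pairs, this does not show whether the place of the amino group or the rest of the core sets that gap. The compounds shown leave open how the 4-aminophenyl group would behave on the core of compound 1. They also leave open whether a hydroxyl or methylamino group in place of the amino group would follow either step.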